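Cyclic Head Group Replaces Open One on Shared Core

The source may report more compounds than this note shows. Statements on the series, on what has been measured and on what is new or still open speak of the compounds shown alone.

Three compounds share a core and a phenoxy-terminated chain. Within the data shown here, in an ADME assay on L6 cells (Rattus norvegicus) for cytotoxicity, read by resazurin assay, with a stated time of 70 h (on this read-out higher numbers stand for weaker inhibition and lower numbers for stronger inhibition), compound 1 `c1ccc(OCCCCOc2ccc(-c3cc4ccc(C5=NCCN5)cc4o3)cc2)cc1` gives 16900 nM, while compound 2 `c1ccc(OCCCCCOc2ccc(-c3cc4ccc(C5=NCCN5)cc4o3)cc2)cc1` gives 3200 nM; the single measured step between them, a 5.3-fold lower number from compound 1 to compound 2 (0.72 log units; beyond the scatter), concerns only the chain. Compound 3 `N=C(N)c1ccc2cc(-c3ccc(OCCCCCCOc4ccccc4)cc3)oc2c1` gives 8000 nM in this assay, which places it second highest of the three numbers: compound 1 sits a little above it and compound 2 below it, both beyond the scatter. Compound 4 `c1ccc(OCCCCCCOc2ccc(-c3cc4ccc(C5=NCCN5)cc4o3)cc2)cc1` keeps the chain and the core of compound 3 and differs from it only at the head group, where (a group of 5 heavy atoms (3 carbon, 2 nitrogen; one five-membered non-aromatic ring with 2 hetero atoms) in place of a group of 3 heavy atoms (1 carbon, 2 nitrogen; no ring), on an aromatic carbon). Among the measured compounds shown here, no measured step addresses this kind of change; the one step in hand, a 5.3-fold lower number from compound 1 to compound 2 (0.72 log units; beyond the scatter), alters the chain and not the head group, so it does not speak to the present substitution. For the measured compounds named here, compound 2 carries the same cyclic head group that enters in compound 4 and gives a lower number than compound 3, but it also differs from compound 3 in the chain, so its value shows only that the cyclic head group is compatible with numbers in this range. Compound 4 is therefore expected to land near compound 3, with a 1.3-fold lower number from compound 3 to compound 4 (0.12 log units; within the scatter) as the anticipated step and an estimated value of 6000 nM, in a range from 2000 nM to 18000 nM.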

Compound 4, half-maximal inhibitory concentration: 3400 nM
Estimate against measurement, compound 4: 1.8-fold (0.25 log units) above, within the range that was stated.
By their numbers in this assay, from the lowest: compounds 2 and 4 (each within the scatter of the next); then compound 3; then compound 1.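

Among these compounds, with the chain and the shared core held fixed, the five-membered non-aromatic ring in place of the open group on the aromatic carbon gives the first measured head-group step in this assay (a 2.4-fold lower number from compound 3 to compound 4 (0.37 log units; beyond the scatter)), and it lies beyond the scatter. Compound 4 also extends the chain comparison among compounds with the ring: 2-phenoxyethyl in place of phenoxy gives a change beyond the scatter (a 5.0-fold lower number from compound 1 to compound 4 (0.70 log units; beyond the scatter)), like the earlier chain step (a 5.3-fold lower number from compound 1 to compound 2 (0.72 log units; beyond the scatter)), whereas phenoxymethyl in place of phenoxy gives a step within the scatter (a 1.1-fold higher number from compound 2 to compound 4 (0.03 log units; within the scatter)), so the chains of compound 2 and compound 4 are not told apart here. No available evidence explains either the head-group step or the chain steps.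

The head-group comparison rests on a single pair, so the compounds shown leave open whether the same change would give a similar step on the chains of compound 1 or compound 2. They also leave open how a longer chain than that of compound 4, or a primary amine or a carboxylic acid on the same aromatic carbon, would read in this assay.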